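The source may report more compounds than this note shows. Statements on the series, on what has been measured and on what is new or still open speak of the compounds shown alone.

Measured in an assay on isolated protein for inhibition of DNA topoisomerase 1 (Homo sapiens), with a stated time of 30 min, tested at 100 uM; on this read-out lower numbers stand for a weaker effect and higher numbers for a stronger effect at the one concentration tested:
compound 1 `O=C(CN1CCN(c2cc3c(cc2F)c(=O)c(C(=O)O)cn3C2CC2)CC1)Nc1ccc(C(=O)/C=C/c2ccccc2Cl)cc1` gives 70.8%
compound 2 `O=C(CN1CCN(c2cc3c(cc2F)c(=O)c(C(=O)O)cn3C2CC2)CC1)Nc1ccc(C(=O)/C=C/c2cccc(Cl)c2)cc1` gives 68.8%
compound 3 `COc1ccc(/C=C/C(=O)c2ccc(NC(=O)CN3CCN(c4cc5c(cc4F)c(=O)c(C(=O)O)cn5C4CC4)CC3)cc2)cc1OC` gives 73.2%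

Compound 1 stands second highest of these three numbers; its nearest neighbour is compound 2, with a number 2 percentage points lower from compound 1 to compound 2 (within the scatter), and its furthest is compound 3, with a number 2.4 percentage points higher from compound 1 to compound 3 (within the scatter), both within the scatter. Compound 4 `COc1cc(/C=C/C(=O)c2ccc(NC(=O)CN3CCN(c4cc5c(cc4F)c(=O)c(C(=O)O)cn5C4CC4)CC3)cc2)cc(OC)c1OC` differs from compound 1 in one place: 3,4,5-trimethoxyphenyl in place of 2-chlorophenyl on a double-bonded chain carbon bound to a double-bonded chain carbon. Among the compounds with values here, the steps that bear on this change are the other exchanges of the group on the double-bonded chain carbon, a number 2.4 percentage points higher from compound 1 to compound 3 (within the scatter) and a number 4.4 percentage points higher from compound 2 to compound 3 (within the scatter), neither of them beyond the scatter. Compound 4 is therefore expected to show a number 1.2 percentage points higher from compound 1 to compound 4 (within the scatter) in this assay, no step beyond the scatter. The estimate for compound 4 is 72%, with a range from 62% to 82%.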

Compound 4, a percentage reported as inhibition, at one concentration (the size of the read-out at that concentration, not a potency): 67.4%
For compound 4 the middle estimate is 4.6 percentage points above the measured one; low and high end bracket the measured number.
By their numbers in this assay, from the lowest: compounds 4, 2, 1 and 3 (each within the scatter of the next).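

In this assay, a further methoxy on an aromatic carbon gives a number 5.8 percentage points lower from compound 3 to compound 4 (within the scatter), and the exchange of either chlorophenyl group gives a number 3.4 percentage points lower from compound 1 to compound 4 (within the scatter) and a number 1.4 percentage points lower from compound 2 to compound 4 (within the scatter). Within the data shown here, the position on a double-bonded chain carbon thus accepts the 3,4,5-trimethoxyphenyl group, with its 12 heavy atoms and 3 hydrogen-bond acceptors, with no step beyond the scatter, extending the flat picture from the earlier compounds to a larger group. Nothing available here offers an explanation for this flatness. As far as these compounds go, whether an amine or a carboxylic acid on this aromatic ring would move the number beyond the scatter remains open.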